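Chloro Beside the Carboxyl: an Unmeasured Analogue

The source may report more compounds than this note shows. Statements on the series, on what has been measured and on what is new or still open speak of the compounds shown alone.

Compound 1 `Cc1c(OCCCCOc2ccc(C(=O)O)cc2)ccc(C(=O)CC2CCCC2)c1C`: "not determined" (no result reported) in an assay on HEK293 cells for positive allosteric modulation of metabotropic glutamate receptor 2 (Rattus norvegicus), read by thallium flux, with a stated time of 2.5 min; on this read-out higher numbers stand for an effect only at larger amounts of compound and lower numbers for an effect already at smaller amounts
Compound 2 `Cc1c(OCCCCOc2ccc(C(=O)O)cc2)ccc(C(=O)CC(C)C)c1C`: "not determined" (no result reported) in this assay
Compound 3 `Cc1c(OCCCCOc2ccc(C(=O)O)cc2)ccc(C(=O)CC(C)C)c1O`: 122 nM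

Three compounds share the same core and the same four-carbon ether linker to the benzoic acid end. Of the three, only compound 3 carries a number: in this assay compound 3 gives 122 nM. Compound 1 and compound 2 carry no number at all: in this assay compound 1 gives "not determined" (no result reported) and compound 2 gives "not determined" (no result reported), so compound 2 stands nowhere on the scale; it is one of two entries without a result. Compound 2 is nevertheless the parent of compound 4 `Cc1c(OCCCCOc2ccc(C(=O)O)c(Cl)c2)ccc(C(=O)CC(C)C)c1C`, which is still to be measured. The change from compound 2 to compound 4 is chloro in place of hydrogen on an aromatic carbon. For the measured compounds named here, no step between two measured compounds is available, so the size of this step is unknown and there is no basis for a direction; the only anchor is the value of compound 3. For compound 4 the half-maximal effective concentration in this assay is therefore expected near 200 nM, with a wide range from 40 nM to 1500 nM.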

Compound 4, half-maximal effective concentration: > 10000 nM
Compound 4: a limit, no number; the forecaster's own chance of this, stated with the estimate: 25%; at least 50-fold (1.69 log units) between middle value and limit.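

In this assay compound 4 gives > 10000 nM, a limit and not a number. For the compounds shown here, compound 2 gives "not determined" (no result reported), so no step from compound 2 to compound 4 can be read. The compounds shown leave open what chloro in place of hydrogen does on this read-out.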